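Acid dissociation across aryl substituents in a cyanooxime amide series

The compounds below may be only part of what the source reports. "The series", "measured", "known", "first", "only" and "open" are said of these compounds alone.

Compound 1 `N#C/C(=N\O)C(=O)Nc1ccc(F)cc1` and compound 2 `N#C/C(=N\O)C(=O)Nc1ccccc1F` share the core of compound 1 and differ only in the placing of a fluoro. In a physicochemical assay for acid dissociation, using potentiometric titration, compound 1 gives 5.01 and compound 2 gives 4.87, a number within the scatter of compound 1, so no order can be read between them. Compound 3 `COc1ccc(NC(=O)/C(C#N)=N/O)cc1` is not yet measured; it differs from compound 1 by methoxy in place of fluoro on an aromatic carbon. Among the compounds with values here, no measured pair covers this change, so a small upward step, or none beyond the scatter, is expected. Compound 3 is estimated at 5.15 in this assay, between 4.85 and 5.45. The step expected is a number 0.14 log units higher from compound 1 to compound 3 (within the scatter).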

Compound 3, acid dissociation constant: 5.08
Compound 3: the middle estimate sits 0.07 log units above what was measured; the range from low to high includes it.
By their numbers in this assay, from the lowest: compounds 2, 1 and 3 (each within the scatter of the next).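

In this assay methoxy in place of fluoro on an aromatic carbon, para to a group of 8 heavy atoms, gives a number 0.07 log units higher from compound 1 to compound 3 (within the scatter) and so adds a change of group at this position to the earlier change in the placing of fluoro. This swap, which brings in a hydrogen-bond acceptor, leaves no step beyond the scatter. Nothing at hand offers an explanation for this result. Still open, on these data alone, is whether an amine or a carboxylic acid at this position would give a step beyond the scatter. Methoxy at the other ring positions also remains open.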